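This account rests on a few compounds, and the source may have more. Where it says the series, first, only, none or still open, it means among the compounds named here.

In a functional assay on B16-F10 cells (Mus musculus) for antiproliferative activity, read by MTT assay, with a stated time of 48 h (a lower number here means a stronger inhibitor, a higher number a weaker inhibitor), three compounds have been measured:

compound 1, `COc1ccc(-c2nn(-c3ccccc3)cc2CNc2ccc(F)cc2)cc1`, gives 6580 nM;
compound 2, `Fc1ccc(NCc2cn(-c3ccccc3)nc2-c2ccc(Br)cc2)cc1`, gives 4180 nM;
compound 3, `COc1ccc(-c2nn(-c3ccccc3)cc2CNc2ccc(Cl)cc2)cc1`, gives 7180 nM.

Compound 2 differs from compound 1 by bromo in place of methoxy on an aromatic carbon, and this brought a 1.6-fold lower number from compound 1 to compound 2 (0.20 log units; within the scatter). Compound 3 differs from compound 1 by chloro in place of fluoro on an aromatic carbon, with a 1.1-fold higher number from compound 1 to compound 3 (0.04 log units; within the scatter). All three numbers thus lie within the scatter of one another, and none can be called the stronger or weaker inhibitor.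

Compound 4, `Clc1ccc(NCc2cn(-c3ccccc3)nc2-c2ccc(Br)cc2)cc1`, has not yet been measured in this assay. It differs from compound 3 by bromo in place of methoxy on an aromatic carbon, the same change that took compound 1 to compound 2; the two cores on which the change is made differ by chloro in place of fluoro on an aromatic carbon. Because that earlier step gave a 1.6-fold lower number from compound 1 to compound 2 (0.20 log units; within the scatter), the step from compound 3 to compound 4 is expected to be of a similar size, a 1.6-fold lower number from compound 3 to compound 4 (0.20 log units; within the scatter), and to stay within the scatter. For compound 4 the estimate in this assay is 4500 nM, with a range from 2200 nM to 9000 nM.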

Compound 4, half-maximal inhibitory concentration: 4290 nM
The estimate for compound 4 lay 1.0-fold (0.02 log units) above the measured number, and the stated range covers the measured number.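

In this assay, bromo in place of methoxy gave a 1.7-fold lower number from compound 3 to compound 4 (0.22 log units; within the scatter), and this step agrees with the same change made on the core of compound 1: the same change on two cores in this assay, a 1.6-fold lower number (0.20 log units; within the scatter) from compound 1 to compound 2 and a 1.7-fold lower number (0.22 log units; within the scatter) from compound 3 to compound 4, 1.1-fold (0.03 log units) apart, within the scatter of two such steps

Chloro in place of fluoro gave a 1.0-fold higher number from compound 2 to compound 4 (0.01 log units; within the scatter), and this step likewise agrees with its counterpart: the same change on two cores in this assay, a 1.1-fold higher number (0.04 log units; within the scatter) from compound 1 to compound 3 and a 1.0-fold higher number (0.01 log units; within the scatter) from compound 2 to compound 4, 1.1-fold (0.03 log units) apart, within the scatter of two such steps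

Going by these compounds alone, both changes thus read alike on the two cores, but every step lies within the scatter, so this agreement shows only that neither change produced a step distinguishable from repeat-measurement noise on either core, not that either has a real effect that carries over.

From the compounds shown here alone, all four compounds hold only methoxy or bromo at the one place and only fluoro or chloro at the other, so it remains open whether an amine, a carboxylic acid or a nitrile at either place would give a step beyond the scatter. Also open is whether these two changes would read alike on cores other than the ones shown here.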